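From compound 2 to compound 3: little change expected

The source may report more compounds than this note shows. Statements on the series, on what has been measured and on what is new or still open speak of the compounds shown alone.

In an ADME assay on MDBK cells (Bos taurus) for cytotoxicity (on this read-out lower numbers stand for higher toxicity in this test and higher numbers for lower toxicity in this test), compound 1 (`COc1ccccc1Cn1ccc2nc(-c3ccccc3)nc-2c1`) reports > 100000 nM as a limit of the assay and not a number. For the measured compounds named here, compound 2 (`Brc1cccc(Cn2ccc3nc(-c4ccccc4)nc-3c2)c1`) gives 85000 nM as the only true number so far, so it cannot yet be ranked against another measured number. Compound 3 (`Ic1ccc(Cn2ccc3nc(-c4ccccc4)nc-3c2)cc1`) is still unmeasured. It carries 4-iodophenyl in place of 3-bromophenyl on a saturated chain carbon bound to an aromatic nitrogen. Going by the values given here, only one measured step bears on this change. That step, an at least 1.1-fold lower number from compound 1 to compound 2 (0.07 log units; that floor lies within the scatter) with 3-bromophenyl in place of 2-methoxyphenyl at the same place, gives only a floor for its size because it starts from the limit of > 100000 nM in this assay, at which 1 of the 2 values shown sits, and so leaves its true size open. With so little to go on, no step beyond the scatter is expected in this assay for this change. The expected change is a 1.1-fold lower number from compound 2 to compound 3 (0.03 log units; within the scatter) and so stays within the scatter. For compound 3 the estimate is 80000 nM with 40000 nM to 100000 nM as the expected range.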

Compound 3, half-maximal cytotoxic concentration: 22000 nM
Beside the measured number, compound 3's estimate is 3.6-fold (0.56 log units) above it, and the stated range ends above it.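

In this assay, the swap of 3-bromophenyl for 4-iodophenyl on a saturated chain carbon bound to an aromatic nitrogen gives a 3.9-fold lower number from compound 2 to compound 3 (0.59 log units; beyond the scatter). For the compounds shown here, this is the first step at this place with a readable size, and it shows that the group here can shift the read-out even when the groups exchanged match in heavy-atom count, hydrogen-bond donors, hydrogen-bond acceptors and net charge. Compound 3 also has the lowest number of the three, as its other step is an at least 4.5-fold lower number from compound 1 to compound 3 (0.65 log units; beyond the scatter), and that size is only a floor because this step starts from a limit: the limit of > 100000 nM in this assay, at which 1 of the 3 values shown sits.

The halogen and the number in the group's name change together from compound 2 to compound 3, so the compounds shown cannot separate the effect of bromine giving way to iodine from the effect of the new ring position, and they give no reason for the drop. From the compounds shown here alone, it also remains open how 4-bromophenyl or 3-iodophenyl would read here, and whether an amine, a carboxylic acid or a longer chain at this place would move the number further.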